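Dioxolane substituent changes in the HUVEC thymidine incorporation series

The compounds below may be only part of what the source reports. "The series", "measured", "known", "first", "only" and "open" are said of these compounds alone.

Measured so far:
compound 1 `CCC(C)n1ncn(-c2ccc(N3CCN(c4ccc(OC[C@@H]5CO[C@@](CC6CCCC6)(c6ccc(Cl)cc6Cl)O5)cc4)CC3)cc2)c1=O`: 512 nM
compound 2 `CCC(C)n1ncn(-c2ccc(N3CCN(c4ccc(OC[C@@H]5CO[C@@](CN6CCNCC6)(c6ccc(Cl)cc6Cl)O5)cc4)CC3)cc2)c1=O`: 608 nM
compound 3 `CCC(C)n1ncn(-c2ccc(N3CCN(c4ccc(OC[C@@H]5CO[C@@](Cn6cnc(C(F)(F)F)n6)(c6ccc(Cl)cc6Cl)O5)cc4)CC3)cc2)c1=O`: 270 nM

In a functional assay on HUVEC cells (Homo sapiens), read by scintillation counting and thymidine incorporation, with a stated time of 24 h (a lower number here means a stronger inhibitor, a higher number a weaker inhibitor), compound 2 gives 608 nM, the highest of the three numbers. Its nearest neighbour is compound 1, with a 1.2-fold higher number from compound 1 to compound 2 (0.07 log units; within the scatter), so these two cannot be told apart. Its furthest is compound 3: a 2.3-fold lower number from compound 2 to compound 3 (0.35 log units; beyond the scatter). The parallel step a 1.9-fold lower number from compound 1 to compound 3 (0.28 log units; within the scatter) points the same way but stays within the scatter.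

Compound 4 `CCC(C)n1ncn(-c2ccc(N3CCN(c4ccc(OC[C@@H]5CO[C@@](Cn6cc(C(F)(F)F)nc6C)(c6ccc(Cl)cc6Cl)O5)cc4)CC3)cc2)c1=O` is the next member. Relative to compound 2 the change is 2-methyl-4-(trifluoromethyl)-1H-imidazol-1-yl in place of piperazin-1-yl on a saturated chain carbon bound to a saturated ring carbon. For the measured compounds named here, the steps that bear on this are the two replacements of cyclopentyl or piperazin-1-yl by 3-(trifluoromethyl)-1H-1,2,4-triazol-1-yl, which gave a modest lowering from compound 2 and a lowering within the scatter from compound 1. Compound 4 carries a trifluoromethyl group on a small aromatic ring in the same place, so a modest step down is expected, a 2.0-fold lower number from compound 2 to compound 4 (0.31 log units; beyond the scatter), landing near compound 3. The estimate for compound 4 in this assay is 300 nM, with a range of 120 nM to 750 nM.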

Compound 4, half-maximal inhibitory concentration: 441 nM
Estimate against measurement, compound 4: 1.5-fold (0.17 log units) below, and the stated range covers the measured number.
By their numbers in this assay, from the lowest: compounds 3, 4, 1 and 2 (each within the scatter of the next, the first and the last beyond it).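

In this assay the 2-methyl-4-(trifluoromethyl)-1H-imidazol-1-yl group cannot be told apart from any of the three earlier groups on this saturated chain carbon bound to a saturated ring carbon (a 1.4-fold lower number from compound 2 to compound 4 (0.14 log units; within the scatter); a 1.6-fold higher number from compound 3 to compound 4 (0.21 log units; within the scatter); a 1.2-fold lower number from compound 1 to compound 4 (0.06 log units; within the scatter)). The separation of 3-(trifluoromethyl)-1H-1,2,4-triazol-1-yl from piperazin-1-yl (a 2.3-fold lower number from compound 2 to compound 3 (0.35 log units; beyond the scatter)) is not repeated here, so a trifluoromethyl group on a five-membered aromatic ring does not always give a step beyond the scatter from piperazin-1-yl. No measurement bearing on these steps is available to explain them.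

Whether the methyl group matters remains open, as 4-(trifluoromethyl)-1H-imidazol-1-yl without it is not among the compounds shown. Also open, as far as these compounds go, is how a carboxylic acid or a longer alkyl chain would read at this place.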